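The source may report more compounds than this note shows. Statements on the series, on what has been measured and on what is new or still open speak of the compounds shown alone.

Compound 2 `CC(C)(C)C(=O)N(CCCCCCN1C[C@H](O)[C@@H](O)[C@H](O)[C@H]1CO)c1ccc(F)cc1F` and compound 1 `CC(C)(C)CC(=O)N(CCCCCCN1C[C@H](O)[C@@H](O)[C@H](O)[C@H]1CO)C1CCCCC1` were both tested in an ADME assay on Huh-7 cells (Homo sapiens) for cytotoxicity, read by MTT assay; a lower number here means that less compound is tolerated, a higher number that more compound is tolerated. In this assay compound 2 gives > 500000 nM, which is a limit of the assay rather than a measured number. In this assay compound 1 gives > 500000 nM, likewise a limit. Compound 2 therefore stands at the limit of > 500000 nM in this assay, at which 2 of the 2 values shown sit. Compound 3 `CC(C)(C)C(=O)N(CCCCCCN1C[C@H](O)[C@@H](O)[C@H](O)[C@H]1CO)C1CCCCCCC1` differs from compound 2 by cyclooctyl in place of 2,4-difluorophenyl on an amide-type nitrogen. Within the data shown here, no measured step between any two compounds is available to guide the size of this change. The step from compound 2 to compound 3 is expected to be a number no higher from compound 2 to compound 3 (the limit leaves the size open), no more than the scatter. Compound 3 is thus expected to give about 500000 nM in this assay, estimated between 150000 nM and 1500000 nM.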

Compound 3, half-maximal cytotoxic concentration: 150000 nM
The estimate for compound 3 lay 3.3-fold (0.52 log units) above the measured number; the measured number falls inside the stated range.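

Cyclooctyl in place of 2,4-difluorophenyl on an amide-type nitrogen gives an at least 3.3-fold lower number from compound 2 to compound 3 (0.52 log units; beyond the scatter) in this assay and shows that the group at this place can change how much compound the cells tolerate. Two limits alone could not show this. Among these compounds, compound 3 is the only compound here with a number rather than a limit: the limit of > 500000 nM in this assay, at which 2 of the 3 values shown sit.

From the compounds shown here alone, the full size of the step stays open, with compound 2 only at a limit. Going by these compounds, whether a pyridine ring or a straight hexyl chain at this nitrogen would behave like cyclooctyl also stays open.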